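The source may hold more compounds than are shown below. What is called first, only, known or untested is meant among the compounds shown, and "the series" means these compounds.

Measured compounds:
compound 1 `Cc1cc(C)n2nc(SCc3nnc(SCc4coc5ccccc5c4=O)n3N)nc2n1` — 1900 nM
compound 2 `Cc1cc(C)n2nc(SCc3nnc(SCc4coc5ccccc5c4=O)n3-c3ccccc3)nc2n1` — 16600 nM
compound 3 `Nc1nc(SCc2coc3ccccc3c2=O)n[nH]1` — 16900 nM

In a functional assay on LM7 cells (Homo sapiens) for cytotoxicity, read by MTT assay, with a stated time of 72 h (on this read-out lower numbers stand for stronger inhibition and higher numbers for weaker inhibition), compound 2 stands second highest of the three numbers. Among the compounds with values here, compound 3 sits within the scatter of it; compound 1 lies well below, and the one measured step, an 8.7-fold higher number from compound 1 to compound 2 (0.94 log units; beyond the scatter), concerns the amino-to-phenyl exchange on the aromatic nitrogen, not the chromone part.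

Compound 4 `Cc1cc(C)n2nc(SCc3nnc(SCc4cc(=O)c5ccccc5o4)n3-c3ccccc3)nc2n1` differs from compound 2 by a group of 11 heavy atoms (9 carbon, 2 oxygen; one six-membered aromatic ring of carbon only, one six-membered aromatic ring with 1 hetero atom) in place of a group of 11 heavy atoms (9 carbon, 2 oxygen; one six-membered aromatic ring of carbon only, one six-membered aromatic ring with 1 hetero atom), on a saturated chain carbon bound to a sulfur — the same atoms joined differently. Within the data shown here, no measured step touches this part of the molecule, so nothing in the data speaks for a change in either direction. The expected step is therefore a 1.0-fold lower number from compound 2 to compound 4 (0.02 log units; within the scatter), none beyond the scatter. Compound 4 is estimated at 16000 nM, within 6000 nM to 45000 nM.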

Compound 4, half-maximal inhibitory concentration: > 25000 nM
Compound 4 ended at the assay's limit; the forecaster's own chance of this, stated with the estimate: 10%; middle value at least 1.5-fold (0.19 log units) from the limit.
By their numbers in this assay, from the lowest: compound 1; then compounds 2 and 3 (each within the scatter of the next). At a limit, above all of these: compound 4.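

In this assay compound 4 gives > 25000 nM, a limit of the assay and not a number. Within the data shown here, this is the first reading on this part of the molecule: the same atoms joined differently, on a saturated chain carbon bound to a sulfur, give an at least 1.5-fold higher number from compound 2 to compound 4 (0.17 log units; that floor lies within the scatter), so the step's floor alone does not separate the pair. The limit stands alone in the set: the limit of > 25000 nM in this assay, at which 1 of the 4 values shown sits.

On these data alone, how far compound 4 lies past its limit stays open. Also open, as far as these compounds go, is whether a plain benzyl group at that chain carbon would read with compound 2 or with compound 4.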